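A few compounds are considered here, and "the series" means these few. Any claim that something is new, unique, unknown or untested is made for them only; others in the source may bear on it.

Compound 1, `COC(C)c1c(NC(=O)Nc2cnc(-n3nccn3)c(Cl)c2)cnc2ccccc12`, is the reference point of this set. In a functional assay on OCI-Ly3 cells (Homo sapiens) for antiproliferative activity (on this read-out higher numbers stand for an effect only at larger amounts of compound and lower numbers for an effect already at smaller amounts), compound 1 gives 620 nM. Compound 2, `COC(C)(C)c1c(NC(=O)Nc2cnc(-n3nccn3)c(Cl)c2)cnc2ccccc12`, differs from it by a single change, (methyl in place of hydrogen on a saturated chain carbon bound to an aromatic carbon, an oxygen on a saturated carbon and a saturated chain carbon), and in this assay compound 2 gives 4430 nM. The step is a 7.1-fold higher number from compound 1 to compound 2 (0.85 log units; beyond the scatter), so adding a methyl at that saturated chain carbon bound to an aromatic carbon, an oxygen on a saturated carbon and a saturated chain carbon costs activity.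

Compound 3, `COC(C)c1c(NC(=O)Nc2cnc(-n3nccn3)c(Cl)c2)cnc2sc(C)nc12`, carries a different core; the difference between its core and that of compound 1 is not broken down here. In this assay compound 3 gives 730 nM, which lies within the scatter of the number for compound 1.

Compound 4, `CCOC(C)c1c(NC(=O)Nc2cnc(-n3nccn3)c(Cl)c2)cnc2sc(C)nc12`, is related to compound 3 by methyl in place of hydrogen on a saturated chain carbon bound to an oxygen on a saturated carbon. This is the same kind of change as that from compound 1 to compound 2, but not the same: in the earlier pair the methyl entered on a saturated chain carbon bound to an aromatic carbon, an oxygen on a saturated carbon and a saturated chain carbon, whereas here it enters on a saturated chain carbon bound to an oxygen on a saturated carbon, turning methoxy into ethoxy. Given that the earlier methyl produced a 7.1-fold higher number from compound 1 to compound 2 (0.85 log units; beyond the scatter), some loss is expected for compound 4 as well, though a smaller one, since the new methyl sits one bond further from the ring; the expected step is a 1.8-fold higher number from compound 3 to compound 4 (0.25 log units; within the scatter). Compound 4 is therefore estimated to give 1300 nM in this assay, expected to fall between 500 nM and 3500 nM.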

Compound 4, half-maximal effective concentration: 360 nM
The estimate for compound 4 lay 3.6-fold (0.56 log units) above the measured number; measured number outside the range, below it.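

In this assay, the methyl added on a saturated chain carbon bound to an oxygen on a saturated carbon, which turns 1-methoxyethyl into 1-ethoxyethyl, gives a 2.0-fold lower number from compound 3 to compound 4 (0.31 log units; beyond the scatter), so the loss seen with the earlier methyl on the core of compound 1 does not reappear here. Set side by side, the two methyl additions run in opposite directions, and the gap between them exceeds what repeated measurement would explain: the same change on two cores in this assay, a 7.1-fold higher number (0.85 log units; beyond the scatter) from compound 1 to compound 2 and a 2.0-fold lower number (0.31 log units; beyond the scatter) from compound 3 to compound 4, 14-fold (1.16 log units) apart, beyond the scatter of two such steps This shows that the effect of adding a methyl to this side chain cannot be carried as a single expected step from one of these cores to the other, but it does not show that the core is responsible, since the methyl also enters on a different carbon in each pair and each result rests on one pair alone.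

The compounds shown leave open how 1-ethoxyethyl behaves on the core of compound 1 and how the methyl on the chain carbon bound to an aromatic carbon behaves on the core of compound 3, the two comparisons that would separate the place of the methyl from the core. They also leave open whether the trend continues to a longer chain such as 1-propoxyethyl, or what an amine would do in place of the ether oxygen.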